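This account rests on a few compounds, and the source may have more. Where it says the series, first, only, none or still open, it means among the compounds named here.

Compound 1 `O=C(NCc1ccc(F)cc1)c1nc(Br)c2cccnc2c1NCc1ccc(F)cc1` carries a 4-fluorobenzyl group on each of its two nitrogens. In a functional assay on HCT-116 cells (Homo sapiens) for cytotoxicity, read by MTT assay, with a stated time of 72 h (a lower number here means a stronger inhibitor, a higher number a weaker inhibitor), compound 1 gives > 20000 nM, which is a limit of the assay rather than a number (the limit of > 20000 nM in this assay, at which 1 of the 2 values shown sits). Compound 2 `N[C@H]1CC[C@H](NC(=O)c2nc(Br)c3cccnc3c2NCc2ccc(F)cc2)CC1` replaces the 4-fluorobenzyl on the amide-type nitrogen with 4-aminocyclohexyl; in this assay compound 2 gives 6400 nM. Within the data shown here, the step of an at least 3.1-fold lower number from compound 1 to compound 2 (0.49 log units; beyond the scatter) is the single measured change in this set. Compound 3 `NCCNc1c(C(=O)NCc2ccc(F)cc2)nc(Br)c2cccnc12` is the next candidate, and it differs from compound 1 as follows: aminomethyl in place of 4-fluorophenyl on a saturated chain carbon bound to a nitrogen on an aromatic ring. Like the step to compound 2, this exchange puts an aminomethyl in place of 4-fluorophenyl, though here on the saturated chain carbon bound to the nitrogen on the aromatic ring rather than on the amide-type nitrogen. Among the measured compounds shown here, only that one measured step bears on the change, and it was at least modest. One therefore expects a step of comparable size in this assay, an at least 2.5-fold lower number from compound 1 to compound 3 (0.39 log units; beyond the scatter), toward a lower number, while allowing that compound 3 may again be reported only as a limit. For compound 3 the estimate in this assay is 8000 nM, within 2500 nM to 30000 nM.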

Compound 3, half-maximal inhibitory concentration: > 20000 nM
Compound 3 gave a limit, no number; the forecaster's own chance of this, stated with the estimate: 40%; at least 2.5-fold (0.39 log units) between middle value and limit.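

In this assay compound 3 gives > 20000 nM and this is a limit, not a number. Among these compounds, compound 1 is also reported only as a limit, so no step from compound 1 to compound 3 can be read: the limit of > 20000 nM in this assay, at which 2 of the 3 values shown sit. The compounds shown leave open whether (2-aminoethyl)amino in place of (4-fluorobenzyl)amino changes the number at all, and in which direction.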